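From 3-chlorobenzyl to 2-chlorobenzyl: a cytotoxicity estimate

A few compounds are considered here, and "the series" means these few. Any claim that something is new, unique, unknown or untested is made for them only; others in the source may bear on it.

Among the compounds with values here, compound 1 `COc1ccc(/C=C2\CN(Cc3cn(Cc4cccc(Cl)c4)nn3)C/C(=C\c3ccc(OC)cc3)C2=O)cc1` gives 99000 nM in a functional assay on MCF7 cells (Homo sapiens) for cytotoxicity, read by MTT assay, with a stated time of 24 h (a lower number here means a stronger inhibitor, a higher number a weaker inhibitor), and holds the higher of the two numbers available so far. Compound 2 `COc1ccc(/C=C2\CN(C(=S)SCc3cn(Cc4cccc(Cl)c4)nn3)C/C(=C\c3ccc(OC)cc3)C2=O)cc1` gives 32000 nM in this assay and stands lower, by a gap beyond the usual scatter. Within the data shown here, these two values are the only guide, since no measured pair differs in just one place. Compound 3 `COc1ccc(/C=C2\CN(Cc3cn(Cc4ccccc4Cl)nn3)C/C(=C\c3ccc(OC)cc3)C2=O)cc1` has not yet been measured, and it differs from compound 1 by 2-chlorophenyl in place of 3-chlorophenyl on a saturated chain carbon bound to an aromatic nitrogen with 2-chlorophenyl in place of 3-chlorophenyl on a saturated chain carbon bound to an aromatic nitrogen. Among the measured compounds shown here, with no measured step to suggest a direction, no step beyond the scatter is expected in this assay for this change. The estimated step of a 1.2-fold lower number from compound 1 to compound 3 (0.07 log units; within the scatter) is accordingly small. For compound 3 the expected value is 85000 nM with an estimated range from 35000 nM to 200000 nM in this measurement.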

Compound 3, half-maximal inhibitory concentration: > 100000 nM
Compound 3 ended at the assay's limit (the forecaster's own chance of this, stated with the estimate: 20%); middle value at least 1.1-fold (0.07 log units) from the limit.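

In this assay compound 3 gives > 100000 nM, which is a limit of the assay and not a number. This is the first look at the chlorine's placement on the benzyl group, and 2-chlorophenyl in place of 3-chlorophenyl on a saturated chain carbon bound to an aromatic nitrogen brings a number no lower from compound 1 to compound 3 (the limit leaves the size open) and the size of this step cannot be read, because the reading stops at the assay's limit: the limit of > 100000 nM in this assay, at which 1 of the 3 values shown sits.

The compounds shown leave open how this position would respond to a group that is not a chlorophenyl, such as a phenyl carrying an amine or a carboxylic acid, or to a longer chain at this place. They also leave open whether 2-chlorobenzyl would give a measurable number on the core of compound 2.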